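Benzyl on the phenol oxygen: stability in rat microsomes

This account rests on a few compounds, and the source may have more. Where it says the series, first, only, none or still open, it means among the compounds named here.

Measured compounds:
- compound 1, `COc1cc(OCc2ccccc2OC)c2cc(-c3cn4nc(OC)sc4n3)oc2c1`, 28%
- compound 2, `COc1cc(OCc2cccc(O)c2)c2cc(-c3cn4nc(OC)sc4n3)oc2c1`, 49%
- compound 3, `COc1cc(OC)c2cc(-c3cn4nc(OC)sc4n3)oc2c1`, 70%

All three share one core and differ only at the ether on the aromatic ring. In an ADME assay on microsomes from liver (Rattus norvegicus) for metabolic stability, with a stated time of 10 min (on this read-out higher numbers stand for a more stable compound and lower numbers for a less stable compound), compound 2 stands second highest of the three: a number 21 percentage points higher from compound 1 to compound 2 (beyond the scatter), and a number 21 percentage points higher from compound 2 to compound 3 (beyond the scatter), both beyond the scatter. The whole spread, a number 42 percentage points higher from compound 1 to compound 3 (beyond the scatter), runs from the largest substituent to none at all.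

Compound 4, `COc1cc(OCc2cccc(OCc3ccccc3)c2)c2cc(-c3cn4nc(OC)sc4n3)oc2c1`, is not yet measured. Its change from compound 2 is benzyl in place of hydrogen on an oxygen on an aromatic ring; cut one bond further out this reads hydroxy to benzyloxy. Going by the values given here, no measured pair adds material at this oxygen, so the nearest guide is the direction of the steps already seen: every step that removed or shortened the group on the ether side raised the number, and compound 4 goes the other way, adding a second ring of carbon only. A modest fall below compound 2 is therefore expected, of about a number 24 percentage points lower from compound 2 to compound 4 (beyond the scatter). For compound 4 the estimate in this assay is 25%, within 10% to 42%.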

Compound 4, percent of the compound remaining: 76%
For compound 4 the middle estimate is 51 percentage points below the measured one, and the stated range ends below it.
By their numbers in this assay, from the lowest: compound 1; then compound 2; then compounds 3 and 4 (each within the scatter of the next).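

In this assay the change from hydroxy to benzyloxy gives a number 27 percentage points higher from compound 2 to compound 4 (beyond the scatter), so added benzyl at this oxygen does not cost stability here. Compound 1, compound 2 and compound 3 alone suggested that a larger group on the ether brings a lower number, but compound 4 goes against that pattern: compound 3 at 70% and compound 4 at 76% lie within the scatter of each other, although only compound 4 carries the two extra rings, so group size alone does not set the number in this series. No available evidence bears on why this step runs upward.

From the compounds shown here alone, it remains open whether the benzyl ring itself matters or whether any cover of the hydroxy would do. A methyl ether, a longer chain or an amine at this oxygen would separate these readings, as would a substituted benzyl.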